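Swapping 4-aminophenyl for pyridin-4-yl on a carbonyl carbon

The source may hold more compounds than are shown below. What is called first, only, known or untested is meant among the compounds shown, and "the series" means these compounds.

Measured in a functional assay on SW 1116 cells (Homo sapiens) for antiproliferative activity, read by MTT assay, with a stated time of 48 h; a higher number here means that more compound is needed for the effect, a lower number that less compound is needed:
Compound 1 `O=C(Nc1nnc(-c2ccc3c(c2)OCCO3)s1)c1ccccc1`: 67.6 ug/mL
Compound 2 `Cc1ccccc1C(=O)Nc1nnc(-c2ccc3c(c2)OCCO3)s1`: > 100 ug/mL, a limit of the assay
Compound 3 `Nc1ccc(C(=O)Nc2nnc(-c3ccc4c(c3)OCCO4)s2)cc1`: 41.2 ug/mL

In this assay compound 3 lies within the scatter of compound 1, and only compound 2 stands apart from it, with an at least 2.4-fold lower number from compound 2 to compound 3 (0.38 log units; beyond the scatter). That step starts from a limit. Compound 4 `O=C(Nc1nnc(-c2ccc3c(c2)OCCO3)s1)c1ccncc1` is still unmeasured, and its change is pyridin-4-yl in place of 4-aminophenyl on a carbonyl carbon. Like compound 1, compound 4 carries no amino group, so the closest measured step is a 1.6-fold lower number from compound 1 to compound 3 (0.22 log units; within the scatter). No step beyond the scatter is therefore expected. The estimate amounts to a 1.3-fold higher number from compound 3 to compound 4 (0.13 log units; within the scatter). For compound 4 the estimated value is 55 ug/mL, with an expected range of 25 ug/mL to 100 ug/mL.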

Compound 4, half-maximal effective concentration: > 100 ug/mL
Compound 4 ended at the assay's limit (the forecaster's own chance of this, stated with the estimate: 15%); middle value at least 1.8-fold (0.25 log units) away from the limit.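

At this place on the carbonyl carbon in this assay, pyridin-4-yl in place of 4-aminophenyl gives an at least 2.4-fold higher number from compound 3 to compound 4 (0.38 log units; beyond the scatter), so a second group, after 2-methylphenyl, now stands beyond the scatter from 4-aminophenyl. The reading for compound 4 is a limit and not a number: the limit of > 100 ug/mL in this assay, at which 2 of the 4 values shown sit. Against phenyl the result is an at least 1.4-fold higher number from compound 1 to compound 4 (0.17 log units; that floor lies within the scatter), a floor that does not separate pyridin-4-yl from phenyl, and the step between the two limits cannot be read.

Going by these compounds, the true size of both readable steps stays open. So does what a hydroxyl in place of the amino group on the phenyl ring, or pyridin-3-yl, would give at this place.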